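This account rests on a few compounds, and the source may have more. Where it says the series, first, only, none or still open, it means among the compounds named here.

Of the compounds shown here, three share a common core and have been tested in a functional assay on MCF7 cells (Homo sapiens) for cytotoxicity, read by MTT assay, with a stated time of 72 h; on this read-out higher numbers stand for weaker inhibition and lower numbers for stronger inhibition. Compound 1, `Cc1ccc(-c2ccc(F)cc2)n1-c1ccc(-c2nc3ccccc3s2)cc1`, gives 3180 nM in this assay. Compound 2, `COc1ccc(-c2ccc(C)n2-c2ccc(-c3nc4ccccc4s3)cc2)cc1`, gives 3260 nM in this assay. Compound 3, `Cc1ccc(-c2ccc(C)n2-c2ccc(-c3nc4ccc(F)cc4s3)cc2)cc1`, gives 2970 nM in this assay, and its values lie within the usual scatter of both compound 1 and compound 2, so no order among the three can be read from these numbers.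

Compound 1 and compound 2 differ in one place, (methoxy in place of fluoro on an aromatic carbon), and this change produced a 1.0-fold higher number from compound 1 to compound 2 (0.01 log units; within the scatter). The difference between the core of compound 1 and the core of compound 3 is not broken down here.

Compound 4, `COc1ccc2nc(-c3ccc(-n4c(C)ccc4-c4ccc(C)cc4)cc3)sc2c1`, has not yet been measured. It differs from compound 3 by methoxy in place of fluoro on an aromatic carbon. Among the measured compounds shown here, this is the same kind of change as the one from compound 1 to compound 2, but not the same: there the place was on an aromatic carbon of a six-membered aromatic ring of carbon only, para to a large group, whereas here it is on an aromatic carbon of a six-membered aromatic ring of carbon only, part of a fused or bridged system of two rings, meta to a fused ring and para to a fused ring.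

Given that the earlier change gave a 1.0-fold higher number from compound 1 to compound 2 (0.01 log units; within the scatter), the step is expected to be a 1.1-fold higher number from compound 3 to compound 4 (0.05 log units; within the scatter) in this assay. Compound 4 is therefore estimated at 3300 nM in this assay, with a range from 1500 nM to 7500 nM, resting on the value of compound 3 and on the step seen from compound 1 to compound 2.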

Compound 4, half-maximal inhibitory concentration: 2850 nM
Compound 4: the middle estimate sits 1.2-fold (0.06 log units) above what was measured; measured number inside the range.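

In this assay, methoxy in place of fluoro on an aromatic carbon of the fused system of two rings gave a 1.0-fold lower number from compound 3 to compound 4 (0.02 log units; within the scatter), so this step can be read only as no detectable change. The earlier step on the other core gave the same picture, and the two steps agree: the same change on two cores in this assay, a 1.0-fold higher number (0.01 log units; within the scatter) from compound 1 to compound 2 and a 1.0-fold lower number (0.02 log units; within the scatter) from compound 3 to compound 4, 1.1-fold (0.03 log units) apart, within the scatter of two such steps

Among the compounds shown here, this shows that, on these two cores and at these two places, the exchange of fluoro for methoxy left the number within the scatter, so the flat result carried over from one core to the other; it does not show that the exchange would stay flat on other cores or at other places, and with only two pairs, in which core and place differ together, the contribution of each cannot be separated.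

The compounds shown carry only fluoro or methoxy at these places, so it remains open whether an amine, a carboxylic acid or a longer chain such as butoxy there would move the number beyond the scatter. All of these numbers also come from a single cell line, which leaves open whether the same flat result would hold in any other cell type.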